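This account rests on a few compounds, and the source may have more. Where it says the series, first, only, none or still open, it means among the compounds named here.

Among the measured compounds shown here, in an in vitro ADME assay on microsomes from liver (Rattus norvegicus) for metabolic stability, read by LC-MS, tested at 1 uM (a lower number here means slower removal, a higher number faster removal of the compound), compound 2 `Cc1ccc(S(=O)(=O)N2CCCCC2C)cc1C#Cc1cc(Cl)ccc1OCC(=O)O` stands highest of the two numbers so far at 418 mL.min-1.g-1, while compound 1 `Cc1ccc(S(=O)(=O)N(C)C(C)C)cc1C#Cc1cc(Cl)ccc1OCC(=O)O` gives 64 mL.min-1.g-1. Compound 3 `Cc1ccc(S(=O)(=O)N(C)CC(C)C)cc1C#Cc1cc(Cl)ccc1OCC(=O)O` is still unmeasured. Its change is isobutyl(methyl)amino in place of 2-methylpiperidin-1-yl on a sulfonyl sulfur. For the measured compounds named here, the one measured step bearing on it is a 6.5-fold higher number from compound 1 to compound 2 (0.81 log units; beyond the scatter), for 2-methylpiperidin-1-yl in place of isopropyl(methyl)amino, and with no ring in the entering group a partial reversal is expected, a 3.2-fold lower number from compound 2 to compound 3 (0.51 log units; beyond the scatter). The estimate for compound 3 is 130 mL.min-1.g-1, with an expected range of 50 mL.min-1.g-1 to 320 mL.min-1.g-1.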

Compound 3, intrinsic clearance in microsomes: 119 mL.min-1.g-1
For compound 3 the middle estimate is 1.1-fold (0.04 log units) above the measured one, within the range that was stated.
By their numbers in this assay, from the lowest: compounds 1 and 3 (each within the scatter of the next); then compound 2.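

In this assay, isobutyl(methyl)amino in place of 2-methylpiperidin-1-yl on the sulfonyl sulfur gives a 3.5-fold lower number from compound 2 to compound 3 (0.55 log units; beyond the scatter) and leaves compound 2 alone at the high end of the three compounds. Isobutyl in place of isopropyl on the sulfonamide nitrogen gives a 1.9-fold higher number from compound 1 to compound 3 (0.27 log units; within the scatter), so the two compounds without a ring cannot be told apart here. No measurement points to a cause for either step. As far as these compounds go, whether the high number goes with the ring or with its methyl stays open, as does how piperidin-1-yl without the methyl or morpholin-4-yl would stand on the sulfonyl sulfur.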